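A few compounds are considered here, and "the series" means these few. Any claim that something is new, unique, unknown or untested is made for them only; others in the source may bear on it.

Compound 3 `COc1ccc([C@@H]2C/C(=N/OCc3cn(-c4cccc(CO)c4)nn3)c3cc(CC=C(C)C)c(OC)cc3O2)cc1` inhibits growth in a functional assay on MCF7 cells (Homo sapiens) for inhibition, read by sulforhodamine B assay, with a stated time of 48 h, tested at 50 uM (on this read-out lower numbers stand for less inhibition of growth and higher numbers for more inhibition of growth at the one concentration tested), at 42% and stands second highest among the three measured compounds. Compound 1 `COc1ccc([C@@H]2C/C(=N/OCc3cn(-c4ccc(Cl)cc4C)nn3)c3cc(CC=C(C)C)c(OC)cc3O2)cc1` gives 37%; the move to 3-(hydroxymethyl)phenyl in place of 4-chloro-2-methylphenyl on an aromatic nitrogen brought a number 5 percentage points higher from compound 1 to compound 3 (within the scatter), within the scatter. Compound 2 `C#CCO/N=C1/C[C@@H](c2ccc(OC)cc2)Oc2cc(OC)c(CC=C(C)C)cc21` gives 61%, beyond the scatter above compound 3.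

Compound 4 `COc1ccc([C@@H]2C/C(=N/OCc3cn(-c4ccc(O)cc4)nn3)c3cc(CC=C(C)C)c(OC)cc3O2)cc1` carries 4-hydroxyphenyl in place of 3-(hydroxymethyl)phenyl on an aromatic nitrogen. Within the data shown here, the only measured step that bears on this is the earlier exchange of the aryl group on the same aromatic nitrogen, which stayed within the scatter, so no shift beyond the scatter is expected here. For compound 4 in this assay the estimate is 42%, ranging from 30% to 55%. The expected step is then no change at the digits printed from compound 3 to compound 4 (within the scatter).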

Compound 4, percent growth inhibition at one concentration: 63%
For compound 4 the middle estimate is 21 percentage points below the measured one, and the stated range ends below it.
By their numbers in this assay, from the lowest: compounds 1 and 3 (each within the scatter of the next); then compounds 2 and 4 (each within the scatter of the next).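

In this assay, the group on this aromatic nitrogen can change the result: 4-hydroxyphenyl in place of 3-(hydroxymethyl)phenyl gives a number 21 percentage points higher from compound 3 to compound 4 (beyond the scatter), and in place of 4-chloro-2-methylphenyl it gives a number 26 percentage points higher from compound 1 to compound 4 (beyond the scatter). Exchanging ethynyl for 1-(4-hydroxyphenyl)-1H-1,2,3-triazol-4-yl gives a number 2 percentage points higher from compound 2 to compound 4 (within the scatter), so that exchange shows no clear change. Nothing here explains the gain from 4-hydroxyphenyl. Still open, on these data alone, is whether an amine or a carboxylic acid in place of the hydroxyl on this phenyl ring would keep that gain.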